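The compounds below may be only part of what the source reports. "The series", "measured", "known", "first", "only" and "open" are said of these compounds alone.

Compound 1 `CC1(C)CN(c2cccnc2)C(=O)c2ccc(Cl)cc21` gives > 10000 nM in an ADME assay on cells for inhibition of cytochrome P450 11B1, mitochondrial (Homo sapiens), read by HTRF (on this read-out higher numbers stand for weaker inhibition and lower numbers for stronger inhibition), a limit of the assay rather than a number (the limit of > 10000 nM in this assay, at which 1 of the 3 values shown sits).
Compound 2 `CC1CN(c2cccnc2)C(=O)c2ccc(Cl)cc21` gives 2590 nM in this assay.
Compound 3 `CC1(C)c2cc(Cl)ccc2C(=O)N1c1cccnc1` gives 4280 nM in this assay.

The change from compound 1 to compound 2 is hydrogen in place of methyl on a saturated ring carbon; it brought an at least 3.8-fold lower number from compound 1 to compound 2 (0.58 log units; beyond the scatter). The values of compound 3 and compound 2 lie within the scatter of each other. The difference between the core of compound 1 and the core of compound 3 is not broken down here. Compound 4 `CC1c2cc(Cl)ccc2C(=O)N1c1cccnc1` differs from compound 3 by hydrogen in place of methyl on a saturated ring carbon; this is the same kind of change as that from compound 1 to compound 2, but it sits on a five-membered rather than a six-membered ring, and next to the ring nitrogen rather than two ring bonds from it. Because compound 1 showed an at least 3.8-fold lower number from compound 1 to compound 2 (0.58 log units; beyond the scatter), a comparable but smaller step is expected, a 2.9-fold lower number from compound 3 to compound 4 (0.46 log units; beyond the scatter). Compound 4 is therefore estimated at 1500 nM in this assay, between 500 nM and 5000 nM.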

Compound 4, half-maximal inhibitory concentration: 1250 nM
Estimate against measurement, compound 4: 1.2-fold (0.08 log units) above; measured number inside the range.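

In this assay, hydrogen in place of methyl on a saturated ring carbon gave a 3.4-fold lower number from compound 3 to compound 4 (0.53 log units; beyond the scatter), so the change points the same way on the core of compound 3 as on the core of compound 1. Set side by side, the two steps read: the same change on two cores in this assay, an at least 3.8-fold lower number (0.58 log units; beyond the scatter) from compound 1 to compound 2 and a 3.4-fold lower number (0.53 log units; beyond the scatter) from compound 3 to compound 4; the limit leaves it open whether they differ. Compound 1 gives > 10000 nM, a limit of the assay and not a number, so the pair shows a shared direction on these two cores but does not show that the change has the same size on both.

The compounds shown leave open whether the step would hold on any further core. They also leave open how an ethyl group or a hydroxymethyl group on that saturated ring carbon would read in this assay.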